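This account rests on a few compounds, and the source may have more. Where it says the series, first, only, none or still open, it means among the compounds named here.

Measured so far:
Compound 1 `C/C(=N/NC(=O)c1ccc(S(N)(=O)=O)cc1)c1ccc(F)cc1`: 31900 nM
Compound 2 `NS(=O)(=O)c1ccc(C(=O)N/N=C\c2ccc(Br)cc2)cc1`: 1370 nM

In a functional assay on MCF7 cells (Homo sapiens) for antiproliferative activity, read by MTT assay (a higher number here means a weaker inhibitor, a lower number a stronger inhibitor), compound 2 gives 1370 nM, the lower of the two numbers and beyond the scatter of the value for compound 1. Compound 3 `NS(=O)(=O)c1ccc(C(=O)N/N=C\c2ccc(F)cc2)cc1` follows from compound 2 by one change: fluoro in place of bromo on an aromatic carbon. Going by the values given here, no measured pair shows this change, so its direction and size remain a judgement. A modest move to a higher number is expected, a 2.6-fold higher number from compound 2 to compound 3 (0.41 log units; beyond the scatter). The estimate for compound 3 is 3500 nM, with an expected range of 900 nM to 14000 nM.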

Compound 3, half-maximal inhibitory concentration: 9170 nM
Compound 3: the middle estimate sits 2.6-fold (0.42 log units) below what was measured, within the range that was stated.
By their numbers in this assay, from the lowest: compound 2; then compound 3; then compound 1.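

Replacing bromo with fluoro on the aromatic carbon para to a large group gives a 6.7-fold higher number from compound 2 to compound 3 (0.83 log units; beyond the scatter) in this assay and so provides the first direct read on this position. The halogen here is not interchangeable, and the bromo compound gives the lower number of this pair. Nothing available explains the difference between these two halogens.

Going by these compounds, whether chloro, an amine or a methoxy group at this position would give a lower or higher number remains open. So does the size of this change on the core of compound 1.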